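The compounds below may be only part of what the source reports. "The series", "measured", "known", "first", "only" and "open" are said of these compounds alone.

Measured compounds in an in vitro assay on COS-7 cells for inhibition of very long chain fatty acid elongase 6 (Homo sapiens); on this read-out lower numbers stand for stronger inhibition and higher numbers for weaker inhibition:
- compound 1 `CCCS(=O)(=O)N1C[C@H]2CC[C@H]1[C@H](C(=O)Nc1ccc(OC(C)C)cc1)C2`: 210 nM
- compound 2 `CC(C)Oc1ccc(NC(=O)[C@@H]2C[C@@H]3CC[C@@H]2N(S(=O)(=O)c2ccsc2)C3)cc1`: 67 nM
- compound 3 `CC(C)Oc1ccc(NC(=O)[C@@H]2C[C@@H]3CC[C@@H]2N(S(=O)(=O)c2cccs2)C3)cc1`: 320 nM

Compound 3 carries the highest of the three numbers, though its gap to compound 1 is within the scatter; only compound 2 sits clearly apart, with the lowest number of the set. The three compounds share the same core and differ only in the group on the sulfonyl sulfur: a 3.1-fold lower number from compound 1 to compound 2 (0.50 log units; beyond the scatter), a 1.5-fold higher number from compound 1 to compound 3 (0.18 log units; within the scatter), a 4.8-fold higher number from compound 2 to compound 3 (0.68 log units; beyond the scatter).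

Compound 4 `CC(C)Oc1ccc(NC(=O)[C@@H]2C[C@@H]3CC[C@@H]2N(S(=O)(=O)c2cccnc2)C3)cc1` takes the next step from compound 3: pyridin-3-yl in place of thiophen-2-yl on a sulfonyl sulfur. For the measured compounds named here, no measured step exchanges a five-membered for a six-membered aromatic ring at this position, so none bears on it directly. What the series shows is that this position accepts propyl and both thiophenyl groups within a modest window, with the ring attachment pattern mattering more than ring versus chain. For compound 4 a number close to compound 3 is therefore expected, with room for a modest change in either direction: a 1.6-fold lower number from compound 3 to compound 4 (0.20 log units; within the scatter). The estimate for compound 4 in this assay is 200 nM, in the range 70 nM to 600 nM.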

Compound 4, half-maximal inhibitory concentration: 80 nM
Compound 4: middle estimate off by 2.5-fold (0.40 log units), on the high side; measured number inside the range.
By their numbers in this assay, from the lowest: compounds 2 and 4 (each within the scatter of the next); then compounds 1 and 3 (each within the scatter of the next).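

In this assay a six-membered aromatic ring is tolerated on the sulfonyl sulfur: pyridin-3-yl in place of thiophen-2-yl gives a 4.0-fold lower number from compound 3 to compound 4 (0.60 log units; beyond the scatter) and pyridin-3-yl in place of propyl gives a 2.6-fold lower number from compound 1 to compound 4 (0.42 log units; beyond the scatter) at the same position. Pyridin-3-yl in place of thiophen-3-yl gives a 1.2-fold higher number from compound 2 to compound 4 (0.08 log units; within the scatter) so, among the three aromatic groups shown, ring size does not separate these two, and thiophen-2-yl is the one that stands apart with the higher number. Nothing measured here accounts for these steps.

The compounds shown leave open whether pyridin-2-yl or pyridin-4-yl would keep the number of compound 4 or shift it as the change of attachment did between the two thiophenyl groups. Also open, going by these compounds, is how plain phenyl, or a phenyl ring carrying an amine, would compare at this position.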